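The source may report more compounds than this note shows. Statements on the series, on what has been measured and on what is new or still open speak of the compounds shown alone.

Of the compounds shown here, three built on a shared core have been measured in a functional assay on MCF7 cells (Homo sapiens) for cytotoxicity, read by MTT assay, with a stated time of 72 h, tested at 3 uM; on this read-out higher numbers stand for more inhibition of growth at the one concentration tested and lower numbers for less inhibition of growth. Compound 1 `Cc1ccnc(/C(N)=N/NC(=S)N2CCCC2)c1` gives 57.7%, compound 3 `N/C(=N\NC(=S)N1CCOCC1)c1ccccn1` gives 44.5%, and compound 2 `N/C(=N\NC(=S)N1CCOCC1)c1ccc(F)cn1` gives 33.9%, the lowest of the three numbers, with compound 3 nearest to it and compound 1 furthest from it. For the measured compounds named here, the single measured step that changes one place is a number 10.6 percentage points higher from compound 2 to compound 3 (beyond the scatter), a hydrogen in place of the fluoro. Compound 4 `N/C(=N\NC(=S)N1CCCC1)c1ccc(F)cn1` has not yet been measured; it differs from compound 2 in one place: pyrrolidin-1-yl in place of morpholin-4-yl on a thiocarbonyl carbon. Going by the values given here, no measured step bears directly on this change. Compound 1 carries the pyrrolidin-1-yl ring and compound 3 the morpholin-4-yl ring, yet the two also differ in the group on an aromatic carbon, so their two values only hint that the pyrrolidin-1-yl ring goes with the higher number. On that hint alone a modest rise is expected, put at a number 9.1 percentage points higher from compound 2 to compound 4 (within the scatter). Compound 4 is therefore estimated at 43%, within a range from 28% to 58%.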

Compound 4, percent growth inhibition at one concentration: 52.6%
Compound 4: the middle estimate sits 9.6 percentage points below what was measured; low and high end bracket the measured number.
By their numbers in this assay, from the lowest: compound 2; then compounds 3, 4 and 1 (each within the scatter of the next, the first and the last beyond it).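

In this assay, pyrrolidin-1-yl in place of morpholin-4-yl on a thiocarbonyl carbon gives a number 18.7 percentage points higher from compound 2 to compound 4 (beyond the scatter) with the fluoro group held constant. For the compounds shown here, this is the first reading of that ring change on its own, since the earlier pair that carried the two rings also differed in the group on an aromatic carbon. It shows that the group on the thiocarbonyl carbon alone can move this read-out beyond the scatter, though nothing available explains the rise.

The compounds shown leave open whether the same ring change gives a similar step on the core of compound 3, where hydrogen stands in place of the fluoro. They also leave open how a piperidin-1-yl ring, a piperazin-1-yl ring or an open-chain dimethylamino group would read at this place.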